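Compound 3 to compound 4: methyl for bromo

A few compounds are considered here, and "the series" means these few. Any claim that something is new, unique, unknown or untested is made for them only; others in the source may bear on it.

In a functional assay on K562 cells (Homo sapiens) for inhibition, read by trypan blue exclusion, with a stated time of 48 h (on this read-out lower numbers stand for stronger inhibition and higher numbers for weaker inhibition), compound 1 `NC(=O)c1cc(Br)ccc1NC(=O)/C=C/c1ccccc1Cl` gives 8100 nM as a measured number. Compound 2 `NC(=O)c1cc(Br)ccc1NC(=O)/C=C/c1cccc(Cl)c1` gives > 10000 nM as a limit. Compound 3 `NC(=O)c1cc(Br)ccc1NC(=O)/C=C/c1ccccc1Br` gives > 10000 nM as a limit too. Compound 4 `Cc1ccccc1/C=C/C(=O)Nc1ccc(Br)cc1C(N)=O` differs from compound 3 by methyl in place of bromo on an aromatic carbon and in nothing else. The closest measured change is an at least 1.2-fold higher number from compound 1 to compound 3 (0.09 log units; that floor lies within the scatter) and the other readable one is an at least 1.2-fold higher number from compound 1 to compound 2 (0.09 log units; that floor lies within the scatter) with both floors inside the scatter. No step beyond the scatter is therefore expected in this assay for this change. The estimated step of a number no higher from compound 3 to compound 4 (the limit leaves the size open) is expected to stay within the scatter. For compound 4 the expected value is 10000 nM with an estimated range from 5000 nM to 20000 nM in this series.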

Compound 4, half-maximal inhibitory concentration: > 10000 nM
Compound 4: only a limit was reported; the forecaster's own chance of this, stated with the estimate: 60%; the middle value lies on the limit itself.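

Compound 4 also ends at a limit in this assay, so at this place, ortho to a large group, methyl gives no measured number, as bromo did in compound 3. Methyl in place of chloro gives an at least 1.2-fold higher number from compound 1 to compound 4 (0.09 log units; that floor lies within the scatter). The steps to compound 4 from compound 2 and from compound 3 cannot be read because both ends of each are limits: the limit of > 10000 nM in this assay, at which 3 of the 4 values shown sit.

Open, from the compounds shown here alone, is whether an amine or a carboxylic acid on this aromatic carbon would return a measured number, as chloro does in compound 1. Going by these compounds, whether compound 1 truly separates from the other compounds also stays open, with every floor within the scatter.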